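This account rests on a few compounds, and the source may have more. Where it says the series, first, only, none or still open, it means among the compounds named here.

In a functional assay on MDA-MB-231 cells (Homo sapiens) for antiproliferative activity, read by MTT assay, with a stated time of 72 h (a higher number here means a weaker inhibitor, a lower number a stronger inhibitor), compound 1 (`NC1=NC2(CCOCC2)N(OCCCOc2ccccc2)C(N)=N1`) is recorded as "not determined" (no result reported) and offers no number for comparison. Compound 2 (`NC1=NC2(CCSCC2)N(OCCCOc2cccc(Cl)c2)C(N)=N1`) gives 130 nM and compound 3 (`NC1=NC2(CCOCC2)N(OCCCOc2cccc(Cl)c2Cl)C(N)=N1`) gives 140 nM in the same read-out. Compound 3 thus lies within the scatter of compound 2, and the two numbers sit level. Compound 4 (`Cc1cc(C)cc(OCCCON2C(N)=NC(N)=NC23CCOCC3)c1`) carries 3,5-dimethylphenyl in place of 2,3-dichlorophenyl on an oxygen on a saturated carbon. Within the data shown here, no measured pair isolates this exchange, so the guide is indirect. In this assay no step beyond the scatter is expected, only a slight drift toward a weaker number, and the estimated move is a 1.4-fold higher number from compound 3 to compound 4 (0.13 log units; within the scatter) on this reading. For compound 4 the estimated value is 190 nM with an expected range from 70 nM to 520 nM in this assay.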

Compound 4, half-maximal inhibitory concentration: 3570 nM
Estimate against measurement, compound 4: 19-fold (1.27 log units) below; the measured number lies above the stated range.
By their numbers in this assay, from the lowest: compounds 2 and 3 (each within the scatter of the next); then compound 4.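

In this assay the group on an oxygen on a saturated carbon is not freely exchangeable: 3,5-dimethylphenyl in place of 2,3-dichlorophenyl brings a 26-fold higher number from compound 3 to compound 4 (1.41 log units; beyond the scatter) on the shared core. The two groups match in heavy-atom count, aromatic ring and hydrogen-bond counts, so those counts do not separate them. Nothing measured on these compounds accounts for the step.

As far as these compounds go, whether the step follows from losing chlorine or from the placement of the substituents stays open. A methoxy group or nitrile on the phenyl ring could test how far this position tolerates change.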